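Chloro to 3-methoxyphenyl: little shift expected

The compounds below may be only part of what the source reports. "The series", "measured", "known", "first", "only" and "open" are said of these compounds alone.

In a functional assay on MCF7 cells (Homo sapiens) for antiproliferative activity (on this read-out lower numbers stand for stronger inhibition and higher numbers for weaker inhibition), compound 1 `Cc1c(OC2CCN(C)CC2)ccc2cc(NC(=O)c3ccc(O)c(CCC(C)C)c3)c(=O)oc12` gives 1250 nM and compound 2 `Cc1c(OC2CCN(C)CC2)ccc2cc(NC(=O)c3ccc(O)c(Cl)c3)c(=O)oc12` gives 1480 nM, so compound 2 stands level with compound 1 within the scatter. Compound 3 `COc1cccc(-c2cc(C(=O)Nc3cc4ccc(OC5CCN(C)CC5)c(C)c4oc3=O)ccc2O)c1` differs from compound 2 as follows: 3-methoxyphenyl in place of chloro on an aromatic carbon. For the measured compounds named here, the only measured step, a 1.2-fold higher number from compound 1 to compound 2 (0.07 log units; within the scatter), puts chloro in place of isopentyl and lies within the scatter. It shows no direction for the new group, and no aryl group has been measured at this carbon, so no shift beyond the scatter is expected. The expected change is a 1.2-fold lower number from compound 2 to compound 3 (0.09 log units; within the scatter). For compound 3 the estimate is 1200 nM, with an expected range of 400 nM to 3500 nM.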

Compound 3, half-maximal inhibitory concentration: 810 nM
For compound 3 the middle estimate is 1.5-fold (0.17 log units) above the measured one; the measured number falls inside the stated range.
By their numbers in this assay, from the lowest: compounds 3, 1 and 2 (each within the scatter of the next).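

In this assay the step to an aromatic ring at this carbon, ortho to a hydroxy group, reads a 1.8-fold lower number from compound 2 to compound 3 (0.26 log units; within the scatter) and the step from the chain reads a 1.5-fold lower number from compound 1 to compound 3 (0.19 log units; within the scatter) so chloro, isopentyl and 3-methoxyphenyl all stand level here. A group of 8 heavy atoms with its own ring therefore gives no shift beyond the scatter at this carbon. Nothing measured accounts for this.

From the compounds shown here alone, whether an amine or a carboxylic acid in place of the methoxy group would shift the number beyond the scatter stays open. So does the effect of replacing the hydroxy group with an amine.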